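Adding a Dichlorophenyl Chain to Compound 3

The source may report more compounds than this note shows. Statements on the series, on what has been measured and on what is new or still open speak of the compounds shown alone.

In a functional assay on cells (T-cell line, Homo sapiens) for inhibition (a lower number here means a stronger inhibitor, a higher number a weaker inhibitor), compound 3 (`CN1CCC(COC(c2ccccc2)c2ccccc2)CC1`) reads > 20000 nM and this is a limit of the assay, not a number. Of the three values in hand, only this one is a limit.

Compound 4 (`Clc1ccc(CCCN2CCC(COC(c3ccccc3)c3ccccc3)CC2)cc1Cl`) differs from compound 3 in one place, counted as 2-(3,4-dichlorophenyl)ethyl in place of hydrogen on a saturated chain carbon bound to an amine nitrogen in a ring in the structure: 2-(3,4-dichlorophenyl)ethyl stands in place of hydrogen on a saturated chain carbon bound to an amine nitrogen in a ring.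

For the measured compounds named here, no measured pair isolates this change, so the guide is indirect. With compound 1 (`COc1ccc(CCCN2CCC(COC(c3ccc(Br)cc3)c3ccc(Br)cc3)CC2)cc1`) at 3200 nM and compound 2 (`COc1ccc(CCCN2CCC(C(O)CC(c3ccccc3)c3ccccc3)CC2)cc1`) at 1500 nM as the nearest guides, a large step toward stronger inhibition, beyond the scatter, is expected in this assay for this change. Both of these compounds carry an aromatic chain on the amine nitrogen, as compound 4 does, though they differ from it elsewhere, so the comparison is a loose one. The estimated step is an at least 9.0-fold lower number from compound 3 to compound 4 (0.95 log units; beyond the scatter) on this reading. For compound 4 the estimated value is 2200 nM with an expected range from 700 nM to 7000 nM in this measurement.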

Compound 4, half-maximal inhibitory concentration: 2200 nM
Beside the measured number, compound 4's estimate shows no gap at the digits printed; low and high end bracket the measured number.
By their numbers in this assay, from the lowest: compounds 2, 4 and 1 (each within the scatter of the next, the first and the last beyond it). At a limit, above all of these: compound 3.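

In this assay, placing 2-(3,4-dichlorophenyl)ethyl in place of hydrogen on a saturated chain carbon bound to an amine nitrogen in a ring gives an at least 9.0-fold lower number from compound 3 to compound 4 (0.95 log units; beyond the scatter). For the compounds shown here, the earlier compounds differ from compound 3 in more than one place, so none of them could tie a shift in this read-out to this one site; this pair is the first to do so, and it shows that this change alone is enough to bring a compound from the limit of the assay to a measurable number. The step has a floor but no known size, because compound 3 stands at a limit and not at a number: the limit of > 20000 nM in this assay, at which 1 of the 4 values shown sits.

The compounds shown leave open how much of the step belongs to the ring, the chlorine atoms or the chain itself, since a plain 2-phenylethyl group, a simple propyl chain or a chain ending in a carboxylic acid do not appear at this site. They also leave open whether a longer chain between the aromatic ring and the amine nitrogen, or fluorine in place of the chlorine atoms, would move the number in either direction.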